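This account rests on a few compounds, and the source may have more. Where it says the series, first, only, none or still open, it means among the compounds named here.

Measured so far in a functional assay on CHO cells for agonist activity at Melanocortin receptor 4 (Homo sapiens), read by a luciferase reporter, with a stated time of 4 h; on this read-out higher numbers stand for an effect only at larger amounts of compound and lower numbers for an effect already at smaller amounts:
compound 1 `COc1ccc(N(C(=O)CN2C=CN(c3ccccc3)C(=O)[C@@H](Cc3n[nH]c4ccccc34)C2=O)C(C)C)cc1` gives 31600 nM; > 30000 nM (2 entries)
compound 2 `COc1ccc(N(C(=O)CN2C=CN(c3ccccc3)C(=O)C(Cc3n[nH]c4ccccc34)C2=O)C(C)C)cc1` gives 708 nM
compound 3 `COc1ccc(N(C(=O)CN2C=CN(c3ccccc3)C(=O)C(Cc3cc[nH]n3)(Cc3n[nH]c4ccccc34)C2=O)C(C)C)cc1` gives 1050 nM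

Of the two numbers, compound 2 has the lowest; its nearest neighbour is compound 3, separated by a 1.5-fold higher number from compound 2 to compound 3 (0.17 log units; within the scatter). Two of the entries for compound 1 are limits of the assay rather than numbers. Compound 4 `COc1ccc(N(C(=O)CN2C=CN(c3cccnc3)C(=O)C(Cc3n[nH]c4ccccc34)C2=O)C(C)C)cc1` differs from compound 2 by pyridin-3-yl in place of phenyl on an amide-type nitrogen in a ring. Going by the values given here, no measured step touches this position; the single step from compound 2 to compound 3 concerns a different ring carbon and stayed within the scatter, so it gives no guide to direction. Compound 4 is therefore expected to sit close to compound 2, with a step of a 1.1-fold higher number from compound 2 to compound 4 (0.05 log units; within the scatter), that is an estimated 800 nM in this assay, ranging from 300 nM to 2500 nM.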

Compound 4, half-maximal effective concentration: 2880 nM
The estimate for compound 4 lay 3.6-fold (0.56 log units) below the measured number; measured number outside the range, above it.
By their numbers in this assay, from the lowest: compounds 2 and 3 (each within the scatter of the next); then compound 4.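

Putting pyridin-3-yl in place of phenyl on the amide-type nitrogen in the ring gives a 4.1-fold higher number from compound 2 to compound 4 (0.61 log units; beyond the scatter) in this assay and so means that more compound is needed for the same effect. Unlike the earlier step on a ring carbon, this one lies beyond the scatter, so this position responds when a single ring carbon of the group becomes nitrogen, with the heavy-atom count unchanged. Nothing at hand explains the direction of this step.

As far as these compounds go, it remains open how pyridin-4-yl, or a phenyl carrying an amine, would fare at this position. From the compounds shown here alone, a much smaller group such as methyl is equally open.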